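The compounds below may be only part of what the source reports. "The series", "measured", "known", "first", "only" and "open" are said of these compounds alone.

Compound 1 `COc1ccc(-n2cnc3c(NC(C4CC4)C4CC4)nc(C)nc32)c(C)c1` gives 47 nM in a functional assay on CHO cells for antagonist activity at corticotropin-releasing factor receptor 1 (Homo sapiens), read by cAMP accumulation; a lower number here means a stronger inhibitor, a higher number a weaker inhibitor.
Compound 2 `COc1ccc(-n2c(C)nc3c(NC(C4CC4)C4CC4)nc(C)nc32)cc1` gives 19 nM in this assay.
Compound 3 `COCc1nc2c(NC(C3CC3)C3CC3)nc(C)nc2n1-c1ccc(OC)cc1` gives 157 nM in this assay.

Compound 3 carries the highest number of the three, so it is the weakest inhibitor measured so far. Compound 4 `COc1ccc(-n2c(CC3CC3)nc3c(NC(C4CC4)C4CC4)nc(C)nc32)cc1` differs from compound 3 by cyclopropyl in place of methoxy on a saturated chain carbon bound to an aromatic carbon. Among the measured compounds shown here, the only measured step that touches this position is an 8.3-fold higher number from compound 2 to compound 3 (0.92 log units; beyond the scatter), where a methoxy replaced hydrogen and the number rose. Going by these compounds, removing that methoxy is therefore expected to pull the number back down, though what a cyclopropyl contributes at this place is untested, so only part of the loss is assumed to be recovered. The expected step is a 3.1-fold lower number from compound 3 to compound 4 (0.50 log units; beyond the scatter). Compound 4 is estimated at 50 nM, with a range from 15 nM to 160 nM.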

Compound 4, inhibition constant: 308 nM
Beside the measured number, compound 4's estimate is 6.2-fold (0.79 log units) below it; measured number above the stated range.
By their numbers in this assay, from the lowest: compound 2; then compound 1; then compounds 3 and 4 (each within the scatter of the next).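

Cyclopropyl in place of methoxy, on a saturated chain carbon bound to an aromatic carbon, gives a 2.0-fold higher number from compound 3 to compound 4 (0.29 log units; within the scatter), so this assay does not separate these two groups here. Cyclopropyl in place of hydrogen at the same carbon gives a 16-fold higher number from compound 2 to compound 4 (1.21 log units; beyond the scatter), which shows that the loss seen with methoxy also appears with a group that has no oxygen. Nothing available explains this loss. Going by these compounds, what an amine or a carboxylic acid would do at this carbon remains open, and so does whether any group there can match the hydrogen of compound 2.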